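The source may report more compounds than this note shows. Statements on the series, on what has been measured and on what is new or still open speak of the compounds shown alone.

For the measured compounds named here, in a functional assay (trachea) with Cavia porcellus as the target (a higher number here means that more compound is needed for the effect, a lower number that less compound is needed), compound 3 `CCCn1cnc2c1c(=O)n(C)c(=O)n2CCC` gives 5000 nM, the second highest of the three numbers measured so far. Compound 1 `CCCn1c(=O)n(CCCO)c(=O)c2[nH]cnc21` gives 5100 nM, which lies within the scatter of compound 3, so the two cannot be told apart. Compound 2 `CCCn1c(=O)n(CCOCC)c(=O)c2[nH]cnc21` gives 70 nM, well below both. Going by the values given here, the only step measured between neighbouring compounds, a 73-fold lower number from compound 1 to compound 2 (1.86 log units; beyond the scatter), came from an ethoxy in place of a hydroxymethyl on a saturated chain carbon, two bonds along the chain from an aromatic nitrogen. Compound 4 `CCCn1c(=O)n(C)c(=O)c2c1ncn2CCC(C)=O` has not yet been measured; it differs from compound 3 by acetyl in place of methyl on a saturated chain carbon, two bonds along the chain from an aromatic nitrogen. Among the compounds with values here, no measured step tests this change itself; the step from compound 1 to compound 2 shows only that altering a chain at such a place can move the number a great deal, without telling which way an acetyl would move it. With nothing pointing firmly one way, a modest lowering at most is expected, as a 1.7-fold lower number from compound 3 to compound 4 (0.22 log units; within the scatter). Compound 4 is therefore estimated at 3000 nM, with a range from 500 nM to 15000 nM.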

Compound 4, half-maximal effective concentration: 12200 nM
For compound 4 the middle estimate is 4.1-fold (0.61 log units) below the measured one; low and high end bracket the measured number.
By their numbers in this assay, from the lowest: compound 2; then compounds 3 and 1 (each within the scatter of the next); then compound 4.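

Acetyl in place of methyl, on a saturated chain carbon two bonds along the chain from an aromatic nitrogen, now has a direct test: in this assay there is a 2.4-fold higher number from compound 3 to compound 4 (0.39 log units; beyond the scatter), so more compound is needed for the effect. This step points the opposite way to a 73-fold lower number from compound 1 to compound 2 (1.86 log units; beyond the scatter), and it is much smaller, which shows that a large lowering does not carry over to this change on this pair. Nothing measured here explains why the number rose.

The compounds shown leave open whether the carbonyl of the acetyl matters or simply the longer group, since one change cannot separate the two. As far as these compounds go, it also remains open how an amine, a carboxylic acid or a longer plain carbon chain would behave at this place.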